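A few compounds are considered here, and "the series" means these few. Any claim that something is new, unique, unknown or untested is made for them only; others in the source may bear on it.

Measured so far in a toxicity assay on HeLa cells (Homo sapiens) for cytotoxicity, read by MTT assay, with a stated time of 24 h; a lower number here means a stronger inhibitor, a higher number a weaker inhibitor:
- compound 1 `Cc1ncc([N+](=O)[O-])n1CC(O)CSC(=S)N1CCN(c2cccc(Cl)c2Cl)CC1`: 1000000 nM
- compound 2 `Cc1ncc([N+](=O)[O-])n1CC(O)CSC(=S)N1CCC(C)CC1`: 1820000 nM
- compound 3 `Cc1nc([N+](=O)[O-])cn1CC(O)CSC(=S)N1CCN(c2cccc(Cl)c2Cl)CC1`: 724000 nM

Within the data shown here, compound 3 gives the lowest of the three numbers, but its gap to compound 1 is within the scatter, as the step of a 1.4-fold lower number from compound 1 to compound 3 (0.14 log units; within the scatter) shows; only compound 2 stands apart from it, beyond the scatter, and compound 2 differs in the ring-bound group rather than in the nitro position, so no single step is recorded for that pair.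

Compound 4 `COc1ccccc1N1CCN(C(=S)SCC(O)Cn2cc([N+](=O)[O-])nc2C)CC1` is not yet measured. It differs from compound 3 as follows: 2-methoxyphenyl in place of 2,3-dichlorophenyl on an amine nitrogen in a ring. Among the measured compounds shown here, no measured step covers an exchange of one aryl group for another on that ring nitrogen. For the measured compounds named here, the only recorded step concerns the nitro position and is within the scatter; the values of compound 2 and compound 3 show only that removing the aryl-bearing ring nitrogen gives a higher number. Going by the values given here, with no direct precedent, the expected step of a 1.4-fold higher number from compound 3 to compound 4 (0.14 log units; within the scatter) is none beyond the scatter. Compound 4 is therefore estimated at 1000000 nM, with a range of 300000 nM to 3500000 nM.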

Compound 4, half-maximal inhibitory concentration: > 5000000 nM
Compound 4 was reported as a limit; the forecaster's own chance of this, stated with the estimate: 20%; middle value at least 5.0-fold (0.69 log units) away from the limit.
By their numbers in this assay, from the lowest: compounds 3, 1 and 2 (each within the scatter of the next, the first and the last beyond it). At a limit, above all of these: compound 4.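

Among these compounds, the step of an at least 6.9-fold higher number from compound 3 to compound 4 (0.83 log units; beyond the scatter) in this assay is the first to pass the scatter for a single change, whereas the only earlier step, a 1.4-fold lower number from compound 1 to compound 3 (0.14 log units; within the scatter), concerned the nitro position. The group on the amine nitrogen in the ring therefore shifts the number here, even though 2-methoxyphenyl and 2,3-dichlorophenyl have the same heavy-atom count and each has one six-membered aromatic ring of carbon only. The figure for compound 4 is a limit and not a number: the limit of > 5000000 nM in this assay, at which 1 of the 4 values shown sits.

Open, as far as these compounds go, is whether the step follows the loss of the chlorine atoms or the arrival of the methoxy group, a question that plain phenyl or 2-chlorophenyl on the same nitrogen would address. Also open, from the compounds shown here alone, is whether the same exchange gives a similar step with the 2-methyl-5-nitro-1H-imidazol-1-yl group of compound 1.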